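This account rests on a few compounds, and the source may have more. Where it says the series, first, only, none or still open, it means among the compounds named here.

Compound 1 `O=C(Nc1cccc(-n2cc(-c3ccncc3)c(-c3cc(O)cc(Cl)c3)n2)c1)Nc1ccc(Cl)c(C(F)(F)F)c1`: -57% in a functional assay on HCT-15 cells (Homo sapiens) for inhibition, read by sulforhodamine B assay, with a stated time of 48 h, tested at 100 uM; on this read-out lower numbers stand for a stronger effect and higher numbers for a weaker effect at the one concentration tested.
Compound 2 `O=C(Nc1cccc(-n2cc(-c3ccncc3)c(-c3cc(O)cc(Cl)c3)n2)c1)Nc1ccc(Cl)c(Cl)c1`: -23% in this assay.

Among the measured compounds shown here, of the two measured compounds, compound 1 stands lowest in this assay, the single known step being a number 34 percentage points higher from compound 1 to compound 2 (beyond the scatter). Compound 3 `COc1cc(Cl)cc(-c2nn(-c3cccc(NC(=O)Nc4ccc(Cl)c(C(F)(F)F)c4)c3)cc2-c2ccncc2)c1` differs from compound 1 at a different place: methyl in place of hydrogen on an oxygen on an aromatic ring, that is, hydroxy becoming methoxy. For the measured compounds named here, no measured step touches that oxygen, so the one step known, a number 34 percentage points higher from compound 1 to compound 2 (beyond the scatter), does not bear on it. With nothing direct to go on, compound 3 is expected to show a step of a number 17 percentage points higher from compound 1 to compound 3 (beyond the scatter), most likely within the scatter or a modest weakening. Compound 3 is therefore estimated at -40%, with a range from -80% to 10%.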

Compound 3, a percentage reported as activity, at one concentration (the size of the read-out at that concentration, not a potency): -90%
For compound 3 the middle estimate is 50 percentage points above the measured one; measured number below the stated range.
By their numbers in this assay, from the lowest: compound 3; then compound 1; then compound 2.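

In this assay, the oxygen on the 3-chloro-5-hydroxyphenyl group proves to be a place where the read-out responds: hydroxy to methoxy gives a number 33 percentage points lower from compound 1 to compound 3 (beyond the scatter), a stronger effect at the one concentration tested. In this pair, then, the free hydroxy is not needed for the effect, and the change runs opposite in direction to a number 34 percentage points higher from compound 1 to compound 2 (beyond the scatter). Nothing available explains this step. On these data alone, whether an ethoxy group or an amine at this place would give a similar step remains open, as does whether methoxy would act the same way on the chloro-bearing compound 2.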